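This account rests on a few compounds, and the source may have more. Where it says the series, first, only, none or still open, it means among the compounds named here.

Measured in a functional assay on U-937 cells (Homo sapiens) for antiproliferative activity, read by MTT assay, with a stated time of 24 h; on this read-out lower numbers stand for stronger inhibition and higher numbers for weaker inhibition:
compound 1, `CCCCNC(=O)COc1ccc(C(=O)c2c(CCCC)oc3ccccc23)cc1`, gives 22800 nM
compound 2, `CCCCc1oc2ccccc2c1C(=O)c1ccc(OCCCC(=O)N2CCCC2)cc1`, gives 7500 nM

Compound 1 stands with the highest number of the two; the nearest neighbour is compound 2, reached by a 3.0-fold lower number from compound 1 to compound 2 (0.48 log units; beyond the scatter). Compound 3, `CCCCc1oc2ccccc2c1C(=O)c1ccc(OCCCC(=O)N2CCCCC2)cc1`, is not yet measured. It differs from compound 1 by 2-((piperidin-1-yl)carbonyl)ethyl in place of butylcarbamoyl on a saturated chain carbon bound to an oxygen on an aromatic ring. For the measured compounds named here, the only step that bears on this change is the one from compound 1 to compound 2, where the chain is lengthened in the same way and the amide closed into a ring of one size smaller; that step was modest and beyond the scatter. Compound 3 is therefore expected to show a step of about the same size and direction, a 3.0-fold lower number from compound 1 to compound 3 (0.48 log units; beyond the scatter), with no clear reason for a larger or smaller shift. The estimate for compound 3 is 7500 nM, with a range from 3000 nM to 19000 nM.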

Compound 3, half-maximal inhibitory concentration: 16600 nM
Compound 3: middle estimate off by 2.2-fold (0.35 log units), on the low side, and the stated range covers the measured number.
By their numbers in this assay, from the lowest: compound 2; then compounds 3 and 1 (each within the scatter of the next).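

In this assay, the ring size of the amide matters at this position: piperidin-1-yl in place of pyrrolidin-1-yl on a carbonyl carbon gives a 2.2-fold higher number from compound 2 to compound 3 (0.35 log units; beyond the scatter) and is the first change shown that leaves the chain untouched. Against butylcarbamoyl, the 2-((piperidin-1-yl)carbonyl)ethyl group gives a 1.4-fold lower number from compound 1 to compound 3 (0.14 log units; within the scatter) and so shows that lengthening the chain and closing the amide into a ring do not alone separate a compound from compound 1. No supporting data explain this difference between the two rings.

Still open, on these data alone, is whether a morpholine or azepane amide on the same chain would follow pyrrolidine or piperidine. The contributions of chain and amide also remain unseparated, and 3-(butylcarbamoyl)propyl or a pyrrolidine amide on the shorter chain would bear on that.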